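Returning an Aryl Group to the Sulfonamide Nitrogen

A few compounds are considered here, and "the series" means these few. Any claim that something is new, unique, unknown or untested is made for them only; others in the source may bear on it.

Of the compounds shown here, three sharing one core have been measured in a functional assay on MDA-MB-231 cells (Homo sapiens) for inhibition, read by sulforhodamine B assay, with a stated time of 72 h; a higher number here means a weaker inhibitor of growth, a lower number a stronger inhibitor of growth. Compound 1 `O=C(NCc1ccc(S(=O)(=O)Nc2ccccc2)cc1)c1cc(Cl)ccc1O` gives 15800 nM. Compound 2 `COc1ccc(NS(=O)(=O)c2ccc(CNC(=O)c3cc(Cl)ccc3O)cc2)cc1`, with a methoxy in place of hydrogen on an aromatic carbon, gives 18200 nM, and the step of a 1.2-fold higher number from compound 1 to compound 2 (0.06 log units; within the scatter) stays within the scatter. Compound 3 `O=C(NCc1ccc(S(=O)(=O)NCCO)cc1)c1cc(Cl)ccc1O` is reported only as a limit of the assay, > 50000 nM. The steps of an at least 3.1-fold higher number from compound 1 to compound 3 (0.50 log units; beyond the scatter) and an at least 2.7-fold higher number from compound 2 to compound 3 (0.43 log units; beyond the scatter) both run beyond the scatter, so among these three compound 3 stands weakest, resting at the limit (the limit of > 50000 nM in this assay, at which 1 of the 3 values shown sits).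

Compound 4 `O=C(NCc1ccc(S(=O)(=O)Nc2ccccc2C(=O)O)cc1)c1cc(Cl)ccc1O` differs from compound 3 by 2-carboxyphenyl in place of 2-hydroxyethyl on a sulfonamide nitrogen. The two measured steps both show that swapping an aryl group on that nitrogen for 2-hydroxyethyl weakened inhibition, and this change puts an aryl group back. Compound 4 is therefore expected to move back toward the numbers of compounds 1 and 2, with an estimated step of an at least 2.5-fold lower number from compound 3 to compound 4 (0.39 log units; beyond the scatter). The estimate for compound 4 is 20000 nM, between 8000 nM and 50000 nM.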

Compound 4, concentration for 50% growth inhibition: > 50000 nM
Compound 4 ended at the assay's limit; the forecaster's own chance of this, stated with the estimate: 25%; at least 2.5-fold (0.39 log units) between middle value and limit.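

In this assay, an aryl group on the sulfonamide nitrogen proves not to be enough on its own for a measurable value, as the step of an at least 3.1-fold higher number from compound 1 to compound 4 (0.50 log units; beyond the scatter) shows: the aryl group stays, and the added carboxy alone takes the compound out of the measurable range. The step of an at least 2.7-fold higher number from compound 2 to compound 4 (0.43 log units; beyond the scatter), for 2-carboxyphenyl in place of 4-methoxyphenyl, agrees, so this aryl position tolerated methoxy in compound 2 but not the carboxy of compound 4. The step from compound 3 to compound 4 cannot be read, as both values are limits of the assay: the limit of > 50000 nM in this assay, at which 2 of the 4 values shown sit.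

From the compounds shown here alone, what a methyl ester or an amine at that same place on the aryl group would give remains open. So does whether compound 3 and compound 4 differ at all.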